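Ethoxy for Ethyl on the Anilino Ring

This account rests on a few compounds, and the source may have more. Where it says the series, first, only, none or still open, it means among the compounds named here.

Compound 1 `CCc1ccc(NC2=CC(=O)c3nc4n(c3C2=O)[C@H]2OC[C@@H](O)[C@H]2OC4)cc1` — 1290 nM in a functional assay on MGC-803 cells (Homo sapiens) for inhibition, read by sulforhodamine B assay; on this read-out lower numbers stand for stronger inhibition and higher numbers for weaker inhibition
Compound 2 `Cc1ccc(NC2=CC(=O)c3c(nc4n3[C@H]3OC[C@@H](O)[C@H]3OC4)C2=O)cc1` — 1550 nM
Compound 3 `O=C1C(N2CCCC2)=CC(=O)c2c1nc1n2[C@H]2OC[C@@H](O)[C@H]2OC1` — > 16000 nM, a limit of the assay and not a number

Among the numbers shown, compound 1 carries the lowest, and compound 2 lies within the scatter of it, so neither is ranked above the other. Compound 3 gives only a limit (the limit of > 16000 nM in this assay, at which 1 of the 3 values shown sits). Among the measured compounds shown here, the single measured step, an at least 10-fold higher number from compound 2 to compound 3 (1.01 log units; beyond the scatter), replaces the whole (4-methylphenyl)amino group with pyrrolidin-1-yl and bears only loosely on a change kept on the phenyl ring. Compound 4 `CCOc1ccc(NC2=CC(=O)c3nc4n(c3C2=O)[C@H]2OC[C@@H](O)[C@H]2OC4)cc1` differs from compound 1 by ethoxy in place of ethyl on an aromatic carbon. Since compound 1 and compound 2 show that methyl and ethyl on that ring give near-identical numbers, no step beyond the scatter is expected. Compound 4 is therefore estimated at 1500 nM in this assay, between 600 nM and 4000 nM. For compound 4 this expectation amounts to a 1.2-fold higher number from compound 1 to compound 4 (0.07 log units; within the scatter).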

Compound 4, half-maximal inhibitory concentration: 1110 nM
Compound 4: the middle estimate sits 1.4-fold (0.13 log units) above what was measured; the measured number falls inside the stated range.
By their numbers in this assay, from the lowest: compounds 4, 1 and 2 (each within the scatter of the next). At a limit, above all of these: compound 3.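

In this assay, ethoxy in place of ethyl on an aromatic carbon, para to a large group, gives a 1.2-fold lower number from compound 1 to compound 4 (0.07 log units; within the scatter). This position, shown earlier with only methyl and ethyl, thus also carries a group with an oxygen and a hydrogen-bond acceptor, with no step beyond the scatter. Nothing measured here accounts for this closeness of the numbers.

The compounds shown leave open whether an amine, a carboxylic acid or a longer chain at this position would give a step beyond the scatter. They also leave open what chlorine or fluorine on that ring would do.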